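A few compounds are considered here, and "the series" means these few. Any claim that something is new, unique, unknown or untested is made for them only; others in the source may bear on it.

Measured compounds:
compound 1 `N#Cc1cnc(NCc2cnccc2C(F)(F)F)cc1NC1CCOCC1` gives 900 nM in an assay on isolated protein for inhibition of protein kinase C theta type (Homo sapiens), read by TR-FRET, with a stated time of 2 h; a lower number here means a stronger inhibitor, a higher number a weaker inhibitor;
compound 2 `CC1(C)[C@@H](C(N)=O)C[C@H]1Nc1cc(NCc2cnccc2C(F)(F)F)ncc1C#N` gives 1.4 nM in this assay.

Compound 2 holds the lowest of these two numbers, and its nearest neighbour is compound 1 at a 640-fold lower number from compound 1 to compound 2 (2.81 log units; beyond the scatter), a change that came from putting 3-carbamoyl-2,2-dimethylcyclobutyl in place of oxan-4-yl on a nitrogen on an aromatic ring. The next compound, compound 3 `CC1(C)[C@@H](Nc2cc(NCc3cnccc3C(F)(F)F)ncc2C#N)C[C@H]1C(N)=O`, keeps every atom and bond of compound 2 and differs only in configuration: the two compounds have the same atoms and bonds and differ only in configuration as drawn: 2 of 2 stereo elements differ (all stereocentres are inverted: mirror images); a stereocentre at a saturated ring carbon is drawn R in compound 2 and S in compound 3; a stereocentre at a saturated ring carbon is drawn S in compound 2 and R in compound 3. No measured step touches a change of configuration alone, so the one step shown, from compound 1 to compound 2, bears on this only indirectly: it marks how much the substituted ring matters at all, which sets the ceiling for what a mirror image could lose. Mirror images of a potent compound are expected to be weaker, often clearly so, so compound 3 is expected to show a step of a 43-fold higher number from compound 2 to compound 3 (1.63 log units; beyond the scatter) in this assay. Compound 3 is therefore estimated at 60 nM, within the range 4 nM to 900 nM.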

Compound 3, half-maximal inhibitory concentration: 140 nM
Compound 3: the middle estimate sits 2.3-fold (0.37 log units) below what was measured; measured number inside the range.
By their numbers in this assay, from the lowest: compound 2; then compound 3; then compound 1.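

Inverting both stereocentres of the cyclobutyl ring gives a 100-fold higher number from compound 2 to compound 3 (2.00 log units; beyond the scatter) in this assay, so at this position the 3-carbamoyl-2,2-dimethylcyclobutyl group does not act by its presence alone: its drawn configuration counts as well. This step can be laid on configuration alone for a simple reason: the fact that compounds 2 and 3 differ only in the configuration as drawn
The mirror image still keeps part of the gain over the oxan-4-yl group, with a 6.4-fold lower number from compound 1 to compound 3 (0.81 log units; beyond the scatter), so only the larger share of the gain seen for compound 2 is tied to the configuration drawn there.

Going by these compounds, both stereocentres differ at once here, so what each contributes alone stays open, and a compound with only one of them inverted would speak to that. On these data alone, whether the carbamoyl group itself is needed also stays open, and a carboxylic acid or a hydroxymethyl group on the same ring could test it.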